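The compounds below may be only part of what the source reports. "The series", "measured", "known", "first", "only" and "open" are said of these compounds alone.

Compound 1 `CC/C=C/CC(=O)O[C@H](CC=C(C)C)C1=CC(=O)c2c(O)ccc(O)c2C1=O` carries a (pent-2-en-1-yl)carbonyl ester on the shared core. In an assay on HeLa cells for inhibition of DNA topoisomerase 1 (Homo sapiens) (on this read-out lower numbers stand for stronger inhibition and higher numbers for weaker inhibition), compound 1 gives 153000 nM, which is the higher of the two numbers reported in this assay. Compound 2 `C/C=C/C=C/C(=O)O[C@H](CC=C(C)C)C1=CC(=O)c2c(O)ccc(O)c2C1=O` is its closest neighbour: in this assay compound 2 gives 130000 nM, and the step of a 1.2-fold lower number from compound 1 to compound 2 (0.07 log units; within the scatter) lies within the scatter. Compound 3 `CCCCCCCCCCCC(=O)O[C@H](CC=C(C)C)C1=CC(=O)c2c(O)ccc(O)c2C1=O` carries a long saturated chain instead; in this assay compound 3 reaches only a limit, > 625000 nM, which is the limit of > 625000 nM in this assay, at which 1 of the 3 values shown sits. The steps of an at least 4.0-fold higher number from compound 1 to compound 3 (0.61 log units; beyond the scatter) and an at least 4.8-fold higher number from compound 2 to compound 3 (0.68 log units; beyond the scatter) show that the long saturated chain weakens inhibition.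

Compound 4 `CC(C)=CC[C@@H](OC(=O)C=C(C)C)C1=CC(=O)c2c(O)ccc(O)c2C1=O` has not yet been measured in this assay. It differs from compound 1 by 2-methylprop-1-en-1-yl in place of pent-2-en-1-yl on a carbonyl carbon. Going by the values given here, this keeps the short, unsaturated character of the chain that compounds 1 and 2 share, and none of the measured steps between such chains moved beyond the scatter. Compound 4 is therefore expected to sit close to compound 1, with a step of a 1.1-fold lower number from compound 1 to compound 4 (0.04 log units; within the scatter). The estimate for compound 4 in this assay is 140000 nM, within 60000 nM to 350000 nM.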

Compound 4, half-maximal inhibitory concentration: 77000 nM
The estimate for compound 4 lay 1.8-fold (0.26 log units) above the measured number; the measured number falls inside the stated range.
By their numbers in this assay, from the lowest: compounds 4, 2 and 1 (each within the scatter of the next). At a limit, above all of these: compound 3.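

In this assay, a third short unsaturated chain on the carbonyl carbon, 2-methylprop-1-en-1-yl, reads like the other two: a 2.0-fold lower number from compound 1 to compound 4 (0.30 log units; within the scatter), and a 1.7-fold lower number from compound 2 to compound 4 (0.23 log units; within the scatter). The undecyl chain remains apart from this new chain too, with an at least 8.1-fold lower number from compound 3 to compound 4 (0.90 log units; beyond the scatter). Compound 3 stands at a limit of the assay, not at a number: the limit of > 625000 nM in this assay, at which 1 of the 4 values shown sits.

The undecyl chain differs from the short chains in both length and saturation, so a short saturated chain such as butyl would be needed to separate the two, and a medium chain such as hexyl to show where along the length the loss begins. As far as these compounds go, how this position would respond to a chain ending in an amine or a carboxylic acid, or to an amide in place of the ester, also remains open.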